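The source may hold more compounds than are shown below. What is called first, only, known or untested is meant among the compounds shown, and "the series" means these compounds.

Three compounds have been measured in an assay on membranes from brain for displacement of a labelled ligand from Neuronal acetylcholine receptor; alpha4/beta2 (Rattus norvegicus), with a stated time of 3 h; a lower number here means a stronger inhibitor, a higher number a weaker inhibitor:
compound 1 `Cc1cc(/C=C2\CCCN=C2c2cccnc2)cc(C)c1O` gives 360 nM
compound 2 `Oc1cccc(/C=C2\CCCN=C2c2cccnc2)c1` gives 1170 nM
compound 3 `CC(=O)c1ccc(/C=C2\CCCN=C2c2cccnc2)cc1` gives 4490 nM

Compound 3 stands at the highest of the three numbers, weakest of the set; compound 2 sits nearest to it and compound 1 furthest, both gaps lying beyond the usual scatter. Compound 4 `Clc1ccc(/C=C2\CCCN=C2c2cccnc2)cc1` has not yet been measured. It differs from compound 3 in one place: chloro in place of acetyl on an aromatic carbon. Within the data shown here, no measured pair shows this change, so its size cannot be read from the data. The expectation is a modest move toward a lower number, of a size near the edge of the scatter, written as a 2.2-fold lower number from compound 3 to compound 4 (0.35 log units; beyond the scatter). Compound 4 is estimated at 2000 nM, within 700 nM to 6000 nM.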

Compound 4, inhibition constant: 970 nM
Beside the measured number, compound 4's estimate is 2.1-fold (0.31 log units) above it; measured number inside the range.
By their numbers in this assay, from the lowest: compound 1; then compounds 4 and 2 (each within the scatter of the next); then compound 3.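

In this assay, chloro in place of acetyl on the aromatic carbon para to a large group gives a 4.6-fold lower number from compound 3 to compound 4 (0.67 log units; beyond the scatter). Among these compounds, this is the first direct reading of a change at this position, and it shows that a group there need not hold the number as high as acetyl does. No measurement at hand explains the step. On these data alone, whether the step reflects the arrival of chloro or the departure of acetyl stays open. A fluoro, a methoxy or an amine at the same place, or a bare hydrogen, would help separate the two.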